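The source may report more compounds than this note shows. Statements on the series, on what has been measured and on what is new or still open speak of the compounds shown alone.

Among the measured compounds shown here, compound 2, with the structure `Cc1cc(Br)c(Oc2nc(Nc3ccc(C#N)cc3)nc3ccccc23)c(Br)c1`, is one of two compounds measured so far in an ADME assay on MT4 cells (Homo sapiens) for cytotoxicity, read by MTT assay, with a stated time of 4 days; on this read-out lower numbers stand for higher toxicity in this test and higher numbers for lower toxicity in this test. In this assay, for the measured compounds named here, compound 2 gives 25000 nM, the lower of the two numbers; the only other measured compound, compound 1 with the structure `N#Cc1ccc(Nc2nc(Oc3ccc(Cl)cc3Cl)c3ccccc3n2)cc1`, gives 32000 nM in this assay, and the step of a 1.3-fold lower number from compound 1 to compound 2 (0.11 log units; within the scatter) is within the scatter. Compound 3, with the structure `Cc1cccc(C)c1Oc1nc(Nc2ccc(C#N)cc2)nc2ccccc12`, has not yet been measured. It differs from compound 2 in one place: 2,6-dimethylphenyl in place of 2,6-dibromo-4-methylphenyl on an oxygen on an aromatic ring. Going by the values given here, only one measured step bears on this change, the step from compound 1 to compound 2, which also exchanged the aryl group on the oxygen and stayed within the scatter. Compound 3 is therefore expected to show no step beyond the scatter in this assay, and its estimated value is 30000 nM, within the range 12000 nM to 80000 nM. This estimate corresponds to the expected step of a 1.2-fold higher number from compound 2 to compound 3 (0.08 log units; within the scatter).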

Compound 3, half-maximal cytotoxic concentration: 35000 nM
Estimate against measurement, compound 3: 1.2-fold (0.07 log units) below; the measured number falls inside the stated range.
By their numbers in this assay, from the lowest: compounds 2, 1 and 3 (each within the scatter of the next).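

In this assay, 2,6-dimethylphenyl in place of 2,6-dibromo-4-methylphenyl on the oxygen gives a 1.4-fold higher number from compound 2 to compound 3 (0.15 log units; within the scatter), so a group of carbon only, with no bromine, stands at this place without a step beyond the scatter. The exchange for 2,4-dichlorophenyl gives a 1.1-fold higher number from compound 1 to compound 3 (0.04 log units; within the scatter), which means that the chlorinated, brominated and halogen-free groups all lie within the scatter of one another in this test. No supporting data bear on why the three groups read alike.

As far as these compounds go, all three compounds carry a six-membered aromatic ring of carbon only on the oxygen, so it remains open whether an amine or a carboxylic acid on that ring would stay within the scatter. From the compounds shown here alone, it is equally open whether a longer chain in place of the ring would do so.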